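Swapping the aryl group on the ring nitrogen of compound 2

The source may report more compounds than this note shows. Statements on the series, on what has been measured and on what is new or still open speak of the compounds shown alone.

Measured so far:
- Compound 1, `COc1ccccc1N1CCN(CCn2c(=O)[nH]c3ccccc32)CC1`: 1840 nM
- Compound 2, `Cc1ccccc1N1CCN(CCn2c(=O)n(-c3ccccc3C)c3ccccc32)CC1`: 18000 nM
- Compound 3, `COc1ccccc1N1CCN(CCCCCn2c(=O)[nH]c3ccccc32)CC1`: 38 nM

All three were tested in an assay on HEK293 cells for displacement of a labelled ligand from 5-hydroxytryptamine receptor 7 (Homo sapiens); on this read-out lower numbers stand for stronger inhibition and higher numbers for weaker inhibition. Compound 2 gives the highest number of the three, so it is the weakest binder in this set. Its nearest neighbour on the scale is compound 1, which shows a clearly lower number, and compound 3 lies far lower still; both gaps are well beyond the usual scatter. Compound 2 differs from compound 1 in more than one part of the molecule, so no single change can be held responsible for that gap.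

The next compound, compound 4, is `COc1cccc(-n2c(=O)n(CCN3CCN(c4ccccc4C)CC3)c3ccccc32)c1`. It keeps the core and the side chain of compound 2 and changes only one thing: 3-methoxyphenyl in place of 2-methylphenyl on an aromatic nitrogen. Going by the values given here, no measured pair in this set isolates that kind of change, so its effect on this assay cannot be read off directly. A modest step toward a lower number is expected, though one that could still fall within the scatter. The step of a 2.0-fold lower number from compound 2 to compound 4 (0.30 log units; within the scatter) is the estimated outcome. Compound 4 is therefore expected to give about 9000 nM, with a plausible range from 2500 nM to 30000 nM.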

Compound 4, inhibition constant: 2500 nM
Compound 4: the middle estimate sits 3.6-fold (0.56 log units) above what was measured; measured number inside the range.
By their numbers in this assay, from the lowest: compound 3; then compounds 1 and 4 (each within the scatter of the next); then compound 2.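

In this assay, going by these compounds alone, placing 3-methoxyphenyl where 2-methylphenyl stood on the aromatic nitrogen gives a 7.2-fold lower number from compound 2 to compound 4 (0.86 log units; beyond the scatter), and this is the first comparison in the set that isolates a single change. It shows that the number responds to the aryl group at this place on the shared core, even with the core and side chain held constant; the step is modest, but it lies beyond the usual scatter. The entering group carries an oxygen and a hydrogen-bond acceptor that the leaving group lacks, but nothing available explains why the number falls.

This one step combines two differences, the change from methyl to methoxy and the change from the 2 to the 3 position on the phenyl ring, so it cannot show which of them matters, and 3-methylphenyl, 2-methoxyphenyl or an unsubstituted phenyl group would be needed to separate them. It also leaves open whether the same swap would give a similar step on a compound with a longer chain, such as the five-carbon pentyl chain.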